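This account rests on a few compounds, and the source may have more. Where it says the series, first, only, none or still open, it means among the compounds named here.

Among the measured compounds shown here, in a functional assay on HUVEC cells (Homo sapiens) for antiproliferative activity, read by MTT assay, with a stated time of 24 h (a lower number here means a stronger inhibitor, a higher number a weaker inhibitor), compound 2 `COc1cc(OC)c(-c2coc3cc(OCc4ccccc4C)ccc3c2=O)cc1OC` gives 4830 nM, the only actual number so far. Compound 1 `C=CCOc1ccc2c(=O)c(-c3cc(OC)c(OC)cc3OC)coc2c1` is reported only as a limit, > 10000 nM. For the measured compounds named here, the single measured step, an at least 2.0-fold lower number from compound 1 to compound 2 (0.31 log units; beyond the scatter), puts 2-methylphenyl in place of vinyl on a saturated chain carbon bound to an oxygen on an aromatic ring.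

Compound 3 `COc1cc(OC)c(-c2coc3cc(OCc4ccccc4C#N)ccc3c2=O)cc1OC` keeps the benzyl ether of compound 2 but has cyano in place of methyl on an aromatic carbon, ortho to a large group, turning 2-methylbenzyl into 2-cyanobenzyl: cyano in place of methyl on an aromatic carbon. The measured step bears on this only loosely, since it changes the whole group and does not test this substituent. In this assay a step within the scatter is therefore expected, with no firm direction. The expected step is a 1.2-fold lower number from compound 2 to compound 3 (0.08 log units; within the scatter). For compound 3 the estimated value is 4000 nM, with an expected range of 1500 nM to 10000 nM.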

Compound 3, half-maximal inhibitory concentration: > 10000 nM
Compound 3: only a limit was reported; the forecaster's own chance of this, stated with the estimate: 20%; at least 2.5-fold (0.39 log units) between middle value and limit.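

On the benzyl ether, the substituent on the aromatic carbon ortho to a large group affects the read-out in this assay: an at least 2.0-fold higher number from compound 2 to compound 3 (0.31 log units; beyond the scatter), with cyano in place of methyl, so the benzyl ether alone does not secure the number seen for compound 2. Compound 3 gives > 10000 nM, which is a limit and not a number. The step linking compound 1 and compound 3 cannot be read, as both values are limits, and only compound 2 has a number: the limit of > 10000 nM in this assay, at which 2 of the 3 values shown sit.

As far as these compounds go, how large the step to 2-cyanobenzyl really is remains open. Also open, from the compounds shown here alone, is whether a chloro group or an amine on the same aromatic carbon, or a carboxylic acid there, would keep, lower or raise the number of compound 2.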